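Nitrophenyl for Fluorophenyl, Read on Vero Cell Tolerance

The source may hold more compounds than are shown below. What is called first, only, known or untested is meant among the compounds shown, and "the series" means these compounds.

Three measured compounds share one core and differ at two places. Compound 1 `O=c1cc(CSc2nc3ccccc3c(=O)[nH]2)c2ccc(OS(=O)(=O)c3ccc(F)cc3)cc2o1` gives 30000 nM in an ADME assay on Vero cells (Chlorocebus sabaeus) for cytotoxicity, read by polymerase chain reaction, with a stated time of 18 h; a lower number here means that less compound is tolerated, a higher number that more compound is tolerated. Compound 2 `O=c1cc(CSc2nc3ccccc3c(=O)[nH]2)c2ccc(OS(=O)(=O)c3ccccc3[N+](=O)[O-])cc2o1` carries 2-nitrophenyl in place of 4-fluorophenyl on a sulfonyl sulfur; the step is a 4.8-fold higher number from compound 1 to compound 2 (0.68 log units; beyond the scatter), and compound 2 gives 144000 nM. Compound 3 `Cc1ccc2nc(SCc3cc(=O)oc4cc(OS(=O)(=O)c5ccc(F)cc5)ccc34)[nH]c(=O)c2c1` differs from compound 1 by methyl in place of hydrogen on an aromatic carbon; the step is a 2.9-fold higher number from compound 1 to compound 3 (0.46 log units; beyond the scatter), and compound 3 gives 86400 nM. Compound 4 `Cc1ccc2nc(SCc3cc(=O)oc4cc(OS(=O)(=O)c5ccccc5[N+](=O)[O-])ccc34)[nH]c(=O)c2c1` is not yet measured; it stands to compound 3 as compound 2 stands to compound 1, with 2-nitrophenyl in place of 4-fluorophenyl on a sulfonyl sulfur, the same change at the same place. In this assay, among the measured compounds shown here, the step from compound 3 is expected to be a 3.5-fold higher number from compound 3 to compound 4 (0.54 log units; beyond the scatter), near the earlier one, because a 4.8-fold higher number from compound 1 to compound 2 (0.68 log units; beyond the scatter) is the only measured instance of this change. Compound 4 is estimated at 300000 nM, between 120000 nM and 800000 nM.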

Compound 4, half-maximal cytotoxic concentration: 107000 nM
Beside the measured number, compound 4's estimate is 2.8-fold (0.45 log units) above it, and the stated range ends above it.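

On the methyl-bearing core, 2-nitrophenyl in place of 4-fluorophenyl gives a 1.2-fold higher number from compound 3 to compound 4 (0.09 log units; within the scatter) in this assay, so the step seen on the core of compound 1 does not carry over in size: the same change on two cores in this assay, a 4.8-fold higher number (0.68 log units; beyond the scatter) from compound 1 to compound 2 and a 1.2-fold higher number (0.09 log units; within the scatter) from compound 3 to compound 4, 3.9-fold (0.59 log units) apart, beyond the scatter of two such steps
Read the other way, the methyl step also depends on the group on the sulfonyl sulfur, at a 1.3-fold lower number from compound 2 to compound 4 (0.13 log units; within the scatter): the same change on two cores in this assay, a 2.9-fold higher number (0.46 log units; beyond the scatter) from compound 1 to compound 3 and a 1.3-fold lower number (0.13 log units; within the scatter) from compound 2 to compound 4, 3.9-fold (0.59 log units) apart, beyond the scatter of two such steps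
This shows that the two changes do not add up across these four compounds, but it does not show why, and a single pair on each core cannot tell which behaviour is typical of the series.

On these data alone, whether an alkyl chain or an amine on the sulfonyl sulfur would also depend on the core remains open. So does whether a chlorine or a methoxy group in place of the methyl would behave as the methyl does.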